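The compounds below may be only part of what the source reports. "The series", "measured", "known", "first", "only" and "open" are said of these compounds alone.

Compound 1 `N#Cc1cc(N/C(=N\O)c2nonc2SCCNC(=O)CS(N)(=O)=O)ccc1F`: in an ADME assay on microsomes from liver (Homo sapiens) for metabolic stability (a higher number here means that the compound lasts longer, a lower number that the compound disappears faster), compound 1 gives > 3 h, which is a limit of the assay and not a number (the limit of > 3 h in this assay, at which 1 of the 3 values shown sits).
Compound 2 `CS(=O)(=O)CC(=O)NCCSc1nonc1/C(=N/O)Nc1ccc(F)c(C(F)F)c1`: in this assay compound 2 gives 1.27 h.
Compound 3 `CS(=N)(=O)CC(=O)NCCSc1nonc1/C(=N/O)Nc1ccc(F)c(Br)c1`: in this assay compound 3 gives 2.65 h.

Among the two numbers that were actually measured, compound 2 stands lowest, and compound 3 lies beyond the usual scatter above it. Compound 4 `N#CCC(=O)NCCSc1nonc1/C(=N/O)Nc1ccc(F)c(C(F)F)c1` has not yet been measured. It differs from compound 2 in one place only: cyano in place of methylsulfonyl on a saturated chain carbon bound to a carbonyl carbon. Among the compounds with values here, no measured pair here carries this change, so there is no step to lean on. In this assay the expected step of a 1.2-fold lower number from compound 2 to compound 4 (0.06 log units; within the scatter) is small, in either direction, and may well sit within the scatter. For compound 4 a half-life of 1.1 h is estimated, in a range from 0.5 h to 2.5 h.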

Compound 4, half-life: 2.77 h
The estimate for compound 4 lay 2.5-fold (0.40 log units) below the measured number; measured number outside the range, above it.
By their numbers in this assay, from the lowest: compound 2; then compounds 3 and 4 (each within the scatter of the next). At a limit, above all of these: compound 1.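

Replacing methylsulfonyl with cyano on a saturated chain carbon bound to a carbonyl carbon gives a 2.2-fold higher number from compound 2 to compound 4 (0.34 log units; beyond the scatter) in this assay. Within the data shown here, this is the first single-place comparison in the set, so it shows that the group at this place alone can change the half-life, even though the rest of the molecule stays the same. Nothing shown here explains why the half-life changes.

Among these compounds, this is only one pair, so it remains open whether the change would carry over with bromine in place of difluoromethyl, as in compound 3. Going by these compounds, how an amine, a carboxylic acid or a longer chain would behave at this place also remains open.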